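From Phenyl to Dichlorophenyl on the Shared Core

This account rests on a few compounds, and the source may have more. Where it says the series, first, only, none or still open, it means among the compounds named here.

Three compounds have been measured in a functional assay, with a stated time of 20 min, tested at 20 uM; a higher number here means a stronger effect of the compound at the concentration tested, a lower number a weaker effect:
Compound 1, `COc1cc(/C=C/C(=O)C2=C(/C=C/c3ccc(O)c(OC)c3)NC(=O)NC2c2ccc(N(C)C)cc2)ccc1O`, gives 82.2%.
Compound 2, `COc1cc(/C=C/C(=O)C2=C(/C=C/c3ccc(O)c(OC)c3)NC(=O)NC2c2cccc([N+](=O)[O-])c2)ccc1O`, gives 33%.
Compound 3, `COc1cc(/C=C/C(=O)C2=C(/C=C/c3ccc(O)c(OC)c3)NC(=S)NC2c2ccccc2)ccc1O`, gives 36.6%.

Compound 3 stands second highest of the three numbers; its value lies within the scatter of compound 2 and beyond the scatter below compound 1. Compound 4, `COc1cc(/C=C/C(=O)C2=C(/C=C/c3ccc(O)c(OC)c3)NC(=S)NC2c2c(Cl)cccc2Cl)ccc1O`, differs from compound 3 by 2,6-dichlorophenyl in place of phenyl on a saturated ring carbon. Among the compounds with values here, only one measured step alters the group at that place: a number 49.2 percentage points lower from compound 1 to compound 2 (beyond the scatter). It exchanged two quite different groups, so it shows only that this place can matter greatly, not which way the present change will go. Within the data shown here, no measured compound carries chlorine on that ring. The expected step is therefore of uncertain direction and probably within the scatter: a number 3.4 percentage points higher from compound 3 to compound 4 (within the scatter). Compound 4 is estimated at 40%, between 20% and 62%.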

Compound 4, a percentage reported as activity, at one concentration (the size of the read-out at that concentration, not a potency): 33.9%
Compound 4: the middle estimate sits 6.1 percentage points above what was measured, and the stated range covers the measured number.
By their numbers in this assay, from the lowest: compounds 2, 4 and 3 (each within the scatter of the next); then compound 1.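

In this assay, the step to 2,6-dichlorophenyl gives a number 2.7 percentage points lower from compound 3 to compound 4 (within the scatter) so the two chlorine atoms on this ring do not separate these two compounds. The earlier step of a number 49.2 percentage points lower from compound 1 to compound 2 (beyond the scatter) showed that this saturated ring carbon can matter greatly, and this result shows that not every exchange there does. Nothing measured here offers a reason for this outcome. Still open, going by these compounds, is how a single chlorine on this ring would behave. On these data alone, a carboxylic acid on the same ring is equally open, and so is 4-(dimethylamino)phenyl on the core of compound 3.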